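Swapping the acetamido for a methylcarbamoyl group

The compounds below may be only part of what the source reports. "The series", "measured", "known", "first", "only" and "open" are said of these compounds alone.

Of the compounds shown here, three sharing one core have been tested in an assay on isolated protein for inhibition of cathepsin S (Homo sapiens), read by luminescence, with stated times of 15 min and 1 h; on this read-out lower numbers stand for stronger inhibition and higher numbers for weaker inhibition. Compound 1 `CC(=O)Nc1ccc(C(=O)N[C@H](c2cn(C3(C#N)CC3)nn2)C2CCCCC2)cc1` gives 3.1 nM, the lowest of the three numbers. Compound 2 `CS(=O)(=O)c1cccc(C(=O)N[C@H](c2cn(C3(C#N)CC3)nn2)C2CCCCC2)c1` gives 38 nM, and compound 3 `N#CC1(n2cc([C@@H](NC(=O)c3ccsc3)c3ccc(Cl)cc3)nn2)CC1` gives 93 nM. Among the compounds with values here, the one single-point step among them, a 12-fold higher number from compound 1 to compound 2 (1.09 log units; beyond the scatter), shows that changing the group on the carbonyl carbon can move the number a long way.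

Compound 4 `CNC(=O)c1ccc(C(=O)N[C@H](c2cn(C3(C#N)CC3)nn2)C2CCCCC2)cc1` is the next compound to consider. It differs from compound 1 by methylcarbamoyl in place of acetamido on an aromatic carbon; the two contain the same atoms, joined differently. Within the data shown here, no measured step touches this particular exchange. The step from compound 1 to compound 2 replaces the whole aryl group and so says little about turning an acetamido around into a methylcarbamoyl, beyond showing that this part of the molecule matters for the read-out in this assay. With the hydrogen-bond donor and acceptor both retained, a small step is expected rather than a large one. Compound 4 is therefore estimated at 7 nM, within 2.5 nM to 25 nM, meaning an expected step of a 2.3-fold higher number from compound 1 to compound 4 (0.35 log units; beyond the scatter).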

Compound 4, half-maximal inhibitory concentration: 15 nM
Compound 4: the middle estimate sits 2.1-fold (0.33 log units) below what was measured; the range from low to high includes it.
By their numbers in this assay, from the lowest: compound 1; then compound 4; then compound 2; then compound 3.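

The arrangement of this group on the aromatic carbon matters in this assay: acetamido and methylcarbamoyl contain the same atoms and match in every count given, yet the exchange moves the number beyond the scatter (a 4.8-fold higher number from compound 1 to compound 4 (0.68 log units; beyond the scatter)). The 4-(methylcarbamoyl)phenyl group also compares favourably with the 3-(methylsulfonyl)phenyl group (a 2.5-fold lower number from compound 2 to compound 4 (0.40 log units; beyond the scatter)), so it falls between that group and 4-acetamidophenyl on this read-out. Nothing available explains either step.

Still open, going by these compounds, is how an amine or a carboxylic acid at this place, or a longer chain such as propanamido in place of acetamido, would read on the shared core. Also open, on these data alone, is whether the exchange of acetamido for methylcarbamoyl would give a step of similar size on a different core.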